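The compounds below may be only part of what the source reports. "The series", "measured", "known", "first", "only" and "open" are said of these compounds alone.

In an ADME assay on THP-1 cells (Homo sapiens) for cytotoxicity (on this read-out higher numbers stand for weaker inhibition and lower numbers for stronger inhibition), the three measured compounds give these numbers:

Compound 1 `COc1ccccc1-c1nnc(-c2ccc(C(=O)N/N=C/c3cccc(O)c3O)cc2)o1`: 102000 nM
Compound 2 `COc1ccccc1-c1nnc(-c2ccc(C(=O)N/N=C/c3cccc(F)c3)cc2)o1`: 353000 nM
Compound 3 `COc1ccc(O)c(/C=N/NC(=O)c2ccc(-c3nnc(-c4ccccc4OC)o3)cc2)c1`: 303000 nM

Compound 2 holds the highest of these three numbers, so among them it is the weakest inhibitor of the cells. Its nearest neighbour is compound 3: the step of a 1.2-fold lower number from compound 2 to compound 3 (0.07 log units; within the scatter) stays within the scatter, so these two cannot be told apart. The step of a 3.5-fold higher number from compound 1 to compound 2 (0.54 log units; beyond the scatter) lies beyond the scatter, as does a 3.0-fold higher number from compound 1 to compound 3 (0.47 log units; beyond the scatter); only compound 1 stands clearly apart.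

Compound 4 `COc1ccccc1-c1nnc(-c2ccc(C(=O)N/N=C/c3cccnc3)cc2)o1` is not yet measured. It differs from compound 2 in one place: pyridin-3-yl in place of 3-fluorophenyl on a carbon with a double bond to nitrogen. All three measured steps vary the same group on the same carbon, so all bear on this change, though none involves pyridin-3-yl. Two of them were modest and one was within the scatter; the swap closest in kind, from compound 2 to compound 3, moved nothing. For this assay the step of a 1.2-fold lower number from compound 2 to compound 4 (0.07 log units; within the scatter) is therefore expected to stay small, with no clear direction. Compound 4 is estimated at 300000 nM, between 120000 nM and 750000 nM.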

Compound 4, half-maximal inhibitory concentration: 167000 nM
Compound 4: middle estimate off by 1.8-fold (0.25 log units), on the high side; the measured number falls inside the stated range.
By their numbers in this assay, from the lowest: compounds 1, 4, 3 and 2 (each within the scatter of the next, the first and the last beyond it).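

On a carbon with a double bond to nitrogen, pyridin-3-yl in place of 3-fluorophenyl gives a 2.1-fold lower number from compound 2 to compound 4 (0.33 log units; beyond the scatter) in this assay, so this simple ring swap moves the number by a modest but readable step, whereas the swap to the 2-hydroxy-5-methoxyphenyl group did not. The other two steps, a 1.8-fold lower number from compound 3 to compound 4 (0.26 log units; within the scatter) and a 1.6-fold higher number from compound 1 to compound 4 (0.21 log units; within the scatter), are both within the scatter, so compound 4 cannot be told apart from either and now links two compounds that do differ clearly from each other. Nothing available here explains why this ring swap shifts the number.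

On these data alone, whether pyridin-2-yl or pyridin-4-yl would behave like pyridin-3-yl remains open. So does the effect at this carbon of a phenyl ring carrying a carboxylic acid or an amine.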